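This account rests on a few compounds, and the source may have more. Where it says the series, first, only, none or still open, it means among the compounds named here.

In a functional assay on HeLa cells (Homo sapiens) for antiproliferative activity (on this read-out higher numbers stand for weaker inhibition and lower numbers for stronger inhibition), compound 2 `CC(=O)O[C@@H]1/C=C(\C)CC[C@]2([C@@](C)(O)C(=O)SCc3oc(=O)oc3C)CC(=O)N([C@H](C)c3nc(cs3)/C=C/C=C/C1=O)[S+]2[O-]` gives 3.9 nM and compound 1 `C/C1=C\[C@@H](O)C(=O)/C=C/C=C/c2csc(n2)[C@@H](C)N2C(=O)C[C@@]([C@@](C)(O)C(=O)SCC(=O)OC(C)(C)C)(CC1)[S+]2[O-]` gives 2.6 nM, two values within the usual scatter of each other. Compound 3 `COC1(O[C@@H]2/C=C(\C)CC[C@]3([C@@](C)(O)C(=O)SCc4oc(=O)oc4C)CC(=O)N([C@H](C)c4nc(cs4)/C=C/C=C/C2=O)[S+]3[O-])CCOCC1` gives 1.4 nM, so compound 2 stands clearly above it on this scale.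

The next compound to consider is compound 4 `C/C1=C\[C@@H](O)C(=O)/C=C/C=C/c2csc(n2)[C@@H](C)N2C(=O)C[C@@]([C@@](C)(O)C(=O)SCc3oc(=O)oc3C)(CC1)[S+]2[O-]`, which differs from compound 2 in one place: hydrogen in place of acetyl on an oxygen on a saturated carbon. In words, hydrogen takes the place of acetyl on an oxygen on a saturated carbon, turning acetoxy into hydroxy.

Among the measured compounds shown here, only one measured step touches this place. With 4-methoxyoxan-4-yl in place of acetyl, the step is a 2.8-fold lower number from compound 2 to compound 3 (0.44 log units; beyond the scatter), a modest change. Compound 1 offers a second clue, since it also carries the hydroxy, although it differs from compound 4 elsewhere, and compound 1 gives 2.6 nM.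

Neither clue points to a large change in this assay, so no shift beyond the scatter is expected. The expected step is a 1.3-fold lower number from compound 2 to compound 4 (0.11 log units; within the scatter), slightly downward if it is real. For compound 4 the estimated value is 3 nM, with an expected range of 1.3 nM to 7 nM.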

Compound 4, half-maximal inhibitory concentration: 4.6 nM
Compound 4: the middle estimate sits 1.5-fold (0.19 log units) below what was measured, within the range that was stated.
By their numbers in this assay, from the lowest: compounds 3, 1, 2 and 4 (each within the scatter of the next, the first and the last beyond it).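

In this assay, hydrogen in place of acetyl leaves the number within the scatter (a 1.2-fold higher number from compound 2 to compound 4 (0.07 log units; within the scatter)), so acetoxy and hydroxy on this saturated carbon cannot be told apart. At the same oxygen, the 4-methoxyoxan-4-yl group is separated from the hydroxy by a step beyond the scatter (a 3.3-fold higher number from compound 3 to compound 4 (0.52 log units; beyond the scatter)), so compound 3 now differs clearly from both of the compounds with the smaller substituents at this position. With the hydroxy held constant, exchanging the two groups of 7 heavy atoms on the saturated chain carbon bound to a sulfur also stays within the scatter (a 1.8-fold higher number from compound 1 to compound 4 (0.25 log units; within the scatter)).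

Nothing measured here explains any of these steps. As far as these compounds go, it remains open how a simple methyl ether, a benzoyl ester or a ring without the methoxy group, such as plain oxan-4-yl, would behave on this oxygen.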